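Ester analogues on a shared core: methoxy for trifluoromethyl

The source may hold more compounds than are shown below. What is called first, only, known or untested is meant among the compounds shown, and "the series" means these compounds.

Two esters of the same core have been measured for antiproliferative activity. Compound 1, `COc1cccc(C(=O)Oc2cc3c(cc2C)[C@@H](C(C)C)CC=C3C)c1`, carries a methoxy on its benzoate ring; in a functional assay on SK-LU-1 cells (Homo sapiens) for antiproliferative activity, read by sulforhodamine B assay, with a stated time of 48 h, tested at 50 uM (a lower number here means less inhibition, a higher number more inhibition at the concentration tested (going by the name of the read-out)), compound 1 gives 24.2%. Compound 2, `Cc1cc2c(C(C)C)ccc(C)c2cc1OC(=O)c1ccc(C(F)(F)F)cc1`, carries a trifluoromethyl instead, and in this assay compound 2 gives 28.7%. Of the two numbers, compound 2 is the higher, but compound 1 sits within the usual scatter of it, so no order between them can be claimed.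

Compound 3, `COc1ccc(C(=O)Oc2cc3c(C)ccc(C(C)C)c3cc2C)cc1`, is not yet measured. Relative to compound 2 it differs in one place: methoxy in place of trifluoromethyl on an aromatic carbon. For the measured compounds named here, no step between measured compounds speaks directly to this change. Because compound 1, with a methoxy, gives 24.2%, the step from compound 2 to compound 3 is expected to be small and within the scatter, a number 3.7 percentage points lower from compound 2 to compound 3 (within the scatter). Compound 3 is thus estimated at 25%, between 12% and 38%.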

Compound 3, a percentage reported as inhibition, at one concentration (the size of the read-out at that concentration, not a potency): 32.8%
For compound 3 the middle estimate is 7.8 percentage points below the measured one; low and high end bracket the measured number.
By their numbers in this assay, from the lowest: compounds 1, 2 and 3 (each within the scatter of the next).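

In this assay, for the compounds shown here, the one direct step at this place reads a number 4.1 percentage points higher from compound 2 to compound 3 (within the scatter), so on this aromatic carbon, para to a large group, methoxy in place of trifluoromethyl leaves the read-out within the scatter. Trifluoromethyl, with 4 heavy atoms and 0 hydrogen-bond acceptors, gives way to methoxy, with 2 heavy atoms and 1 hydrogen-bond acceptor, and at this one position the assay does not separate the two. Nothing available gives a reason for this result.

Going by these compounds, whether an amine, a carboxylic acid or a longer alkoxy chain at this place would move the number beyond the scatter stays open. On these data alone, each number comes from a single concentration, so potency also stays open, as does whether this change would read the same on the core of compound 1.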